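From benzyl to (2,6-dichlorophenyl)carbamoyl on a ring amine

The compounds below may be only part of what the source reports. "The series", "measured", "known", "first", "only" and "open" are said of these compounds alone.

Compound 1 `NC(=O)c1c(NC(=O)c2ccccc2Cl)sc2c1CCN(Cc1ccccc1)C2` was tested in a functional assay on HL-60 cells (Homo sapiens) for antiproliferative activity, with a stated time of 24 h (a higher number here means a weaker inhibitor, a lower number a stronger inhibitor), where compound 1 gives 12000 nM. A second compound, compound 2 `NC(=O)c1c(NC(=O)c2ccc(C(F)(F)F)cc2)sc2c1CCN(Cc1ccc(Cl)cc1Cl)C2`, carries different groups at two places on the shared core and gives 14900 nM in this assay. Compound 1 stands alongside compound 2: the two numbers lie within the usual scatter of each other, so these data do not tell them apart, and both describe weak inhibitors. Compound 3 `NC(=O)c1c(NC(=O)c2ccccc2Cl)sc2c1CCN(C(=O)Nc1c(Cl)cccc1Cl)C2` keeps the core of compound 1 and differs from it in a single place: (2,6-dichlorophenyl)carbamoyl in place of benzyl on an amine nitrogen in a ring. Among the measured compounds shown here, no measured pair shows what this kind of change does here, so any expectation rests on the two values alone and on the fact that the rest of the molecule is unchanged. In this assay the change is expected to move the number little, a 1.2-fold lower number from compound 1 to compound 3 (0.08 log units; within the scatter), a step that may well fall within the scatter. Compound 3 is therefore estimated at 10000 nM in this assay, within a range from 3000 nM to 35000 nM.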

Compound 3, half-maximal inhibitory concentration: 17700 nM
Compound 3: the middle estimate sits 1.8-fold (0.25 log units) below what was measured; the range from low to high includes it.
By their numbers in this assay, from the lowest: compounds 1, 2 and 3 (each within the scatter of the next).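

Among the compounds shown here, this is the first direct look at the amine nitrogen in the ring: in this assay, putting (2,6-dichlorophenyl)carbamoyl in place of benzyl gives a 1.5-fold higher number from compound 1 to compound 3 (0.17 log units; within the scatter), so the two compounds cannot be told apart. The exchange is not a small one on paper, since benzyl has 7 heavy atoms and neither a hydrogen-bond donor nor an acceptor, whereas the entering group has 11 heavy atoms, 1 hydrogen-bond donor and 1 hydrogen-bond acceptor, yet compound 3 remains a weak inhibitor like compound 1. No measurement at hand offers an explanation for this result.

The compounds shown leave open whether the two chlorine atoms matter to this result, which a plain phenylcarbamoyl group on the same nitrogen could test. They also leave open whether a quite different group at this position, such as a carboxylic acid or a chain ending in an amine, would move the number beyond the usual scatter of repeated measurements.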